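Swapping the Silicon Group in Compound 2

A few compounds are considered here, and "the series" means these few. Any claim that something is new, unique, unknown or untested is made for them only; others in the source may bear on it.

Compound 1 `CC(C)=CCC[C@]1(C)/C=C/[C@@H](OC(=O)C=C(C)C)[C@](C)(O)/C=C/C(=O)/C(CCl)=C\C1`: 150 nM
Compound 2 `CC(C)=CCC[C@]1(C)/C=C/[C@@H](OC(=O)C=C(C)C)[C@](C)(O)/C=C/C(=O)/C(C[Si](C)(C)C(C)(C)C)=C\C1`: 4200 nM

In a functional assay on A549 cells (Homo sapiens) for antiproliferative activity, read by MTT assay, with a stated time of 48 h (on this read-out lower numbers stand for stronger inhibition and higher numbers for weaker inhibition), compound 2 has the higher of the two numbers, 4200 nM, so it is the weaker inhibitor here. Compound 3 `CSC(=S)OC/C1=C/C[C@](C)(CCC=C(C)C)/C=C/[C@@H](OC(=O)C=C(C)C)[C@](C)(O)/C=C/C1=O` has not been measured. It differs from compound 2 as follows: a group of 5 heavy atoms (2 carbon, 1 oxygen, 2 sulfur; no ring) in place of a group of 7 heavy atoms (6 carbon, 1 silicon; no ring), on a saturated chain carbon bound to a double-bonded ring carbon. Going by the values given here, one measured step bears on this place, a 28-fold higher number from compound 1 to compound 2 (1.45 log units; beyond the scatter), and it is large. Going by these compounds, a change that removes the same silicon group is therefore expected to give a sizeable drop in this assay, though the entering group is untested. The expected step is a 7.0-fold lower number from compound 2 to compound 3 (0.85 log units; beyond the scatter). The estimate for compound 3 is 600 nM, with an expected range of 150 nM to 2500 nM.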

Compound 3, half-maximal inhibitory concentration: 380 nM
Compound 3: the middle estimate sits 1.6-fold (0.20 log units) above what was measured, within the range that was stated.
By their numbers in this assay, from the lowest: compound 1; then compound 3; then compound 2.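

In this assay, the weak result for compound 2 is not a fixed feature of this place: replacing its silicon group with the sulfur-containing group recovers most of the lost activity, with an 11-fold lower number from compound 2 to compound 3 (1.04 log units; beyond the scatter). The chlorine atom still gives the lower number, with a 2.5-fold higher number from compound 1 to compound 3 (0.40 log units; beyond the scatter), so this new group does not fully match it on this saturated chain carbon. Nothing measured here explains why these groups differ. Going by these compounds, it remains open whether an amine, a hydroxyl group or a longer carbon chain at this place would come closer to compound 1 or surpass it.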